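The source may report more compounds than this note shows. Statements on the series, on what has been measured and on what is new or still open speak of the compounds shown alone.

Compounds measured so far:
- compound 1 `Cc1cc(F)cnc1N1CCN(C(=O)CCS(=O)(=O)c2cccc3ncsc23)[C@@H](C)C1`: 9.6% in an ADME assay on microsomes from liver (Rattus norvegicus) for metabolic stability, read by LC-MS, with a stated time of 15 min, tested at 1 uM; on this read-out higher numbers stand for a more stable compound and lower numbers for a less stable compound
- compound 2 `Cc1ccncc1N1CCN(C(=O)CCS(=O)(=O)c2cccc3ncsc23)CC1`: "not determined" (no result reported) in this assay
- compound 3 `Cc1cc(F)cnc1N1CCN(C(=O)CCCc2cccc3cncnc23)[C@@H](C)C1`: "not determined" (no result reported) in this assay

Compound 3 therefore has no number of its own in this assay, and compound 2 is the one further entry without a number; only compound 1 gives a value, and that value is low. Compound 4 `Cc1cc(F)cnc1N1CCN(C(=O)CCCc2cccc3ncsc23)[C@@H](C)C1` differs from compound 3 in one place: 1,3-benzothiazol-7-yl in place of quinazolin-8-yl on a saturated chain carbon, three bonds along the chain from a carbonyl carbon. For the measured compounds named here, no step between measured compounds is known, so no size or direction can be read for this change; the expectation rests on compound 1 alone. Compound 4 shares its ring system with compound 1, and the low reading of compound 1 in this assay suggests a low value is to be expected. Compound 4 is expected to give about 12% in this assay, estimated between 3% and 35%.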

Compound 4, percent of the compound remaining: 5.3%
The estimate for compound 4 lay 6.7 percentage points above the measured number, and the stated range covers the measured number.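

Compound 3 offers no number to set against compound 4, so no new step can be read. From the compounds shown here alone, whether 1,3-benzothiazol-7-yl in place of quinazolin-8-yl alters stability stays open, and no further data bear on this result.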